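Swapping the aryl group on the hydrazone arm

The compounds below may be only part of what the source reports. "The series", "measured", "known", "first", "only" and "open" are said of these compounds alone.

Compound 1 `COc1cc2c(Oc3ccc(NC(=O)N/N=C/c4ccc(Cl)cc4Cl)cc3F)ccnc2cc1OCCCN1CCCCC1` gives 750 nM in a functional assay on MDA-MB-231 cells (Homo sapiens) for cytotoxicity, read by MTT assay, with a stated time of 72 h; a higher number here means a weaker inhibitor, a lower number a stronger inhibitor.
Compound 2 `COc1cc2c(Oc3ccc(NC(=O)N/N=C/c4ccncc4)cc3F)ccnc2cc1OCCCN1CCCCC1` gives 1400 nM in this assay.
Compound 3 `COc1cc2c(Oc3ccc(NC(=O)N/N=C/c4cc5ccccc5[nH]4)cc3F)ccnc2cc1OCCCN1CCCCC1` gives 980 nM in this assay.

Compound 1 holds the lowest of the three numbers shown, but its gaps to compound 2 and compound 3 both fall within the usual scatter, so none of the three can be set apart from the others. The three compounds share one core and differ only in the aryl group on a carbon with a double bond to nitrogen. Compound 4 `COc1cc2c(Oc3ccc(NC(=O)N/N=C/c4cccs4)cc3F)ccnc2cc1OCCCN1CCCCC1` carries a new group at that same place: thiophen-2-yl in place of 2,4-dichlorophenyl on a carbon with a double bond to nitrogen. Going by the values given here, two measured steps bear on this change, both starting from compound 1 and both replacing the same 2,4-dichlorophenyl group: a 1.9-fold higher number from compound 1 to compound 2 (0.27 log units; within the scatter) and a 1.3-fold higher number from compound 1 to compound 3 (0.12 log units; within the scatter). Among the compounds with values here, neither a six-membered ring with one hetero atom nor a fused ring system moved the number beyond the scatter, so a five-membered ring with one hetero atom is expected to behave alike, with no step in this assay beyond the scatter in either direction. Compound 4 is therefore estimated at 900 nM in this assay, in a range from 400 nM to 2200 nM, which means an expected step of a 1.2-fold higher number from compound 1 to compound 4 (0.08 log units; within the scatter).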

Compound 4, half-maximal inhibitory concentration: 1260 nM
Compound 4: the middle estimate sits 1.4-fold (0.15 log units) below what was measured; the measured number falls inside the stated range.
By their numbers in this assay, from the lowest: compounds 1, 3, 4 and 2 (each within the scatter of the next).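

Thiophen-2-yl has 5 heavy atoms against 8 for 2,4-dichlorophenyl, and it brings sulfur into the ring, yet this swap gives a 1.7-fold higher number from compound 1 to compound 4 (0.23 log units; within the scatter). The comparisons with the other two groups stay just as close, with a 1.3-fold higher number from compound 3 to compound 4 (0.11 log units; within the scatter) and a 1.1-fold lower number from compound 2 to compound 4 (0.05 log units; within the scatter). In this assay, a five-membered ring with one hetero atom therefore joins the three earlier aromatic groups on the carbon with a double bond to nitrogen, and no two of these four compounds can be set apart. Nothing measured here explains why the numbers stay so close.

The compounds shown leave open whether a group without an aromatic ring at this place, such as a carboxylic acid, an amine or a longer carbon chain, would give a step beyond the scatter.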